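This account rests on a few compounds, and the source may have more. Where it says the series, first, only, none or still open, it means among the compounds named here.

Series measured in a functional assay on the whole organism (strain Kunming) for inhibition, with Mus musculus as the target, in the writhing test, with stated times of 1 h and 15 min, at a dose of 200 mg/kg by the oral route; on this read-out lower numbers stand for less inhibition and higher numbers for more inhibition at the one dose given (going by the name of the read-out):

compound 1, `Cc1ccc(/C=C2\CCCC(CN(C)c3ccc(C)cc3)C2=O)cc1`, gives 76.6%
compound 2, `Cc1ccc(/C=C2\CCCC(CN(C)c3cccc(C)c3)C2=O)cc1`, gives 75.8%
compound 3, `Cc1ccc(N(C)CC2CCC/C(=C\c3ccc(S(C)(=O)=O)cc3)C2=O)cc1`, gives 84.5%

Compound 1 and compound 2 differ by 3-methylphenyl in place of 4-methylphenyl on an amine nitrogen; the step is a number 0.8 percentage points lower from compound 1 to compound 2 (within the scatter). The step from the core of compound 1 to the core of compound 3 is a number 7.9 percentage points higher from compound 1 to compound 3 (within the scatter). Compound 3 carries the highest number of the three, but its steps to compound 1 and to compound 2 both sit within the scatter, so no order among the three can be drawn from this assay.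

Compound 4, `Cc1cccc(N(C)CC2CCC/C(=C\c3ccc(S(C)(=O)=O)cc3)C2=O)c1`, has not yet been measured in this assay. It differs from compound 3 by 3-methylphenyl in place of 4-methylphenyl on an amine nitrogen. This is the same change already made from compound 1 to compound 2: the group that leaves, the group that enters and the place are the same word for word. The two cores on which the change is made differ by methylsulfonyl in place of methyl on an aromatic carbon, a change that in this assay stayed within the scatter.

For compound 4 the step from compound 3 is expected to be a number 1.5 percentage points lower from compound 3 to compound 4 (within the scatter), because the same change on the core of compound 1 gave a number 0.8 percentage points lower from compound 1 to compound 2 (within the scatter). Compound 4 is therefore estimated at 83%, with the expected range running from 73% to 92%. For the measured compounds named here, the range is kept wide since only one earlier instance of the change is available and it lies within the scatter.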

Compound 4, a percentage reported as inhibition, in the whole organism at one dose (the size of the read-out at that dose, not a potency): 72.8%
For compound 4 the middle estimate is 10.2 percentage points above the measured one; measured number below the stated range.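

In this assay, 3-methylphenyl in place of 4-methylphenyl on the amine nitrogen gives a number 11.7 percentage points lower from compound 3 to compound 4 (beyond the scatter), while the same change on the core of compound 1 stayed within the scatter, yet the gap between the two steps is no larger than two such steps can scatter: the same change on two cores in this assay, a number 0.8 percentage points lower (within the scatter) from compound 1 to compound 2 and a number 11.7 percentage points lower (beyond the scatter) from compound 3 to compound 4, 10.9 percentage points apart, within the scatter of two such steps
The other change in the square of four compounds, methylsulfonyl in place of methyl on an aromatic carbon, gives a number 3 percentage points lower from compound 2 to compound 4 (within the scatter), and beside its earlier instance it likewise shows no gap beyond the scatter: the same change on two cores in this assay, a number 7.9 percentage points higher (within the scatter) from compound 1 to compound 3 and a number 3 percentage points lower (within the scatter) from compound 2 to compound 4, 10.9 percentage points apart, within the scatter of two such steps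
Carrying either change from one core to the other is therefore not shown to alter its step, but it is not shown to leave the step intact either, since a single pair of steps per change can neither establish nor exclude a dependence on the core.

The compounds shown leave open whether a step of this size on the amine side recurs with a plain phenyl or a morpholine in place of the methyl(4-methylphenyl)amino group. They also leave open how a nitrile or a carboxylic acid in place of methylsulfonyl would behave on either core.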